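Sulfonyl aryl series: chloro to fluoro on the sulfonyl ring

The source may report more compounds than this note shows. Statements on the series, on what has been measured and on what is new or still open speak of the compounds shown alone.

Measured compounds:
compound 1 `CC(O)(CS(=O)(=O)c1ccc(Cl)cc1)c1nc(-c2ccc(Cl)cc2)no1` — > 100000 nM
compound 2 `CC(O)(CSc1ccc(F)cc1)c1nc(-c2ccc([N+](=O)[O-])c(C(F)(F)F)c2)no1` — 5100 nM

In a functional assay on DU-145 cells (Homo sapiens) for cytotoxicity, read by MTT assay (on this read-out lower numbers stand for stronger inhibition and higher numbers for weaker inhibition), compound 1 gives > 100000 nM. This is a limit of the assay and not a number, so compound 1 stands only at the limit of > 100000 nM in this assay, at which 1 of the 2 values shown sits, and carries no value of its own for comparison. Compound 2, which carries a thioether in place of the sulfonyl and a different aryl group on the shared core, gives 5100 nM in this assay. Compound 2 and compound 1 differ in more than one place, so no single step can be read between them; their two values show only that one is a limit and the other a number.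

Compound 3 `CC(O)(CS(=O)(=O)c1ccc(F)cc1)c1nc(-c2ccc(Cl)cc2)no1` is not yet measured. It differs from compound 1 in one place: fluoro in place of chloro on an aromatic carbon. Among the compounds with values here, no measured pair isolates this change, so nothing here shows its effect in this assay. The expected step from compound 1 to compound 3 is none beyond the scatter, a number no higher from compound 1 to compound 3 (the limit leaves the size open), with the result most likely again a limit. Compound 3 is estimated at 100000 nM, within 30000 nM to 300000 nM.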

Compound 3, half-maximal inhibitory concentration: > 100000 nM
Compound 3 gave a limit, no number; the forecaster's own chance of this, stated with the estimate: 70%; the middle value lies on the limit itself.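

In this assay compound 3 gives > 100000 nM, a limit of the assay and not a number. Compound 1 stands at the same limit, so no step can be read between compound 1 and compound 3: the limit of > 100000 nM in this assay, at which 2 of the 3 values shown sit.

The compounds shown leave open how 4-chlorophenyl and 4-fluorophenyl on the sulfonyl compare in this assay.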